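Boronic acid chalcones: a ring swap on the carbonyl side

This account rests on a few compounds, and the source may have more. Where it says the series, first, only, none or still open, it means among the compounds named here.

Measured so far:
compound 1 `O=C(/C=C/c1ccc2c(c1)B(O)OC2)c1ccc(Cl)cc1`, 3700 nM
compound 2 `O=C(/C=C/c1ccc2c(c1)B(O)OC2)c1ccc(Cl)c(Cl)c1`, 1800 nM

For the measured compounds named here, in a functional assay on SK-OV-3 cells (Homo sapiens) for cytotoxicity, read by MTT assay, with a stated time of 48 h (on this read-out higher numbers stand for weaker inhibition and lower numbers for stronger inhibition), compound 1 gives the higher of the two numbers; the sole measured step is a 2.1-fold lower number from compound 1 to compound 2 (0.31 log units; beyond the scatter). Compound 3 `Nc1cccc(C(=O)/C=C/c2ccc3c(c2)B(O)OC3)c1` is not yet measured. It differs from compound 1 by 3-aminophenyl in place of 4-chlorophenyl on a carbonyl carbon. Going by the values given here, no measured step touches this position, so the chloro step from compound 1 to compound 2 gives no direction for it. The expectation is a step near or just beyond the scatter, with the wider uncertainty on the weaker side: a 1.4-fold higher number from compound 1 to compound 3 (0.13 log units; within the scatter). Compound 3 is therefore estimated at 5000 nM, within 1500 nM to 16000 nM.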

Compound 3, half-maximal inhibitory concentration: 7400 nM
The estimate for compound 3 lay 1.5-fold (0.17 log units) below the measured number; measured number inside the range.
By their numbers in this assay, from the lowest: compound 2; then compounds 1 and 3 (each within the scatter of the next).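

In this assay, for the compounds shown here, replacing 4-chlorophenyl with 3-aminophenyl on the carbonyl carbon gives a 2.0-fold higher number from compound 1 to compound 3 (0.30 log units; within the scatter), the first reading at this position. Across this exchange, the two groups are not told apart, even though 3-aminophenyl carries a hydrogen-bond donor and acceptor that 4-chlorophenyl lacks. No evidence is available to explain this result. Because the substituent and its ring position change together, their separate contributions remain unresolved. From the compounds shown here alone, it also remains open how 3-chlorophenyl, or a carboxylic acid on this ring, would read.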